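The compounds below may be only part of what the source reports. "The series", "measured", "known", "first", "only" and "open" are said of these compounds alone.

Working notes on the series, all read in a functional assay on HT-29 cells (Homo sapiens) for inhibition, read by MTT assay, with a stated time of 48 h; a lower number here means a stronger inhibitor, a higher number a weaker inhibitor. Compound 1 `COc1cc(-c2cc(-c3ccc(Cl)cc3)nc(-c3ccccc3)n2)cc(OC)c1OC`, the chloro member, gives 6230 nM. Compound 2 `COc1cc(-c2cc(-c3ccc(Br)cc3)nc(-c3ccccc3)n2)cc(OC)c1OC`, the bromo member, gives 3170 nM. The exchange of chloro for bromo is a 2.0-fold lower number from compound 1 to compound 2 (0.29 log units; within the scatter), so these two compounds count as equal here.

Compound 3 `COc1cc(-c2cc(-c3cccc(O)c3)nc(-c3ccccc3)n2)cc(OC)c1OC`, which carries a 3-hydroxyphenyl group, reads > 25000 nM, and this is a limit of the assay, not a number. It therefore stands on the weak side of both halogen compounds, with only a bound on the gap.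

Compound 4 `COc1cc(-c2cc(-c3ccccc3)nc(-c3ccccc3)n2)cc(OC)c1OC` is the next to be read. The change is hydrogen in place of hydroxy on an aromatic carbon, meta to a large group, so that 3-hydroxyphenyl becomes phenyl. Among the measured compounds shown here, no measured step isolates this change. The nearest evidence is an at least 4.0-fold higher number from compound 1 to compound 3 (0.60 log units; beyond the scatter) and an at least 7.8-fold higher number from compound 2 to compound 3 (0.89 log units; beyond the scatter), and both exchange the whole substituted phenyl group. Compound 4 carries neither the hydroxy of compound 3 nor the halogen of compound 1 and compound 2, so it is expected to fall between them, and a reading as a limit remains possible. A modest step to a lower number is expected, estimated as an at least 2.2-fold lower number from compound 3 to compound 4 (0.35 log units; beyond the scatter). For compound 4 the expected value is 11000 nM, with an estimated range of 4000 nM to 30000 nM.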

Compound 4, half-maximal inhibitory concentration: 7930 nM
For compound 4 the middle estimate is 1.4-fold (0.14 log units) above the measured one; low and high end bracket the measured number.
By their numbers in this assay, from the lowest: compounds 2, 1 and 4 (each within the scatter of the next, the first and the last beyond it). At a limit, above all of these: compound 3.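

The phenyl of compound 4 gives a reading in this assay where the 3-hydroxyphenyl of compound 3 gave none, so the loss seen with compound 3 belongs to the hydroxy itself and not merely to the absence of a halogen: an at least 3.1-fold lower number from compound 3 to compound 4 (0.49 log units; beyond the scatter). The halogens add little on this evidence, since hydrogen in place of chloro gives a 1.3-fold higher number from compound 1 to compound 4 (0.10 log units; within the scatter), while hydrogen in place of bromo gives a 2.5-fold higher number from compound 2 to compound 4 (0.40 log units; beyond the scatter), a modest step that leaves only the bromo of compound 2 with a readable gain over the unsubstituted phenyl. The true size of the hydroxy step stays unknown because compound 3 stands at a limit of the assay and not at a number: the limit of > 25000 nM in this assay, at which 1 of the 4 values shown sits.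

The compounds shown leave open whether the effect of hydroxy depends on its place on the phenyl, since the halogens and the hydroxy do not share a position in this set. They also leave open how a methoxy, an amine or a carboxylic acid would read meta to a large group, and so whether the hydroxy stands alone in this loss.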